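The source may report more compounds than this note shows. Statements on the series, on what has been measured and on what is new or still open speak of the compounds shown alone.

Measured so far:
compound 1 `Cc1ccc(NC2=CC(=O)c3c(nc4n3[C@H]3OC[C@@H](O)[C@H]3OC4)C2=O)cc1C`: 1050 nM
compound 2 `COc1cccc(NC2=CC(=O)c3nc4n(c3C2=O)[C@H]2OC[C@@H](O)[C@H]2OC4)c1`: 1780 nM
compound 3 `O=C1C(NC2CCCC2)=CC(=O)c2c1nc1n2[C@H]2OC[C@@H](O)[C@H]2OC1`: > 16000 nM, a limit of the assay and not a number

In a functional assay on MGC-803 cells (Homo sapiens) for inhibition, read by sulforhodamine B assay (on this read-out lower numbers stand for stronger inhibition and higher numbers for weaker inhibition), compound 2 and compound 1 sit within the scatter of each other, so no order between them can be read; compound 3 gave only a limit (the limit of > 16000 nM in this assay, at which 1 of the 3 values shown sits). Compound 4 `O=C1C=C(NC2CCCCC2)C(=O)c2c1nc1n2[C@H]2OC[C@@H](O)[C@H]2OC1` carries cyclohexyl in place of 3-methoxyphenyl on an amine nitrogen. Within the data shown here, one measured step bears on it: an at least 15-fold higher number from compound 1 to compound 3 (1.18 log units; beyond the scatter), where a saturated carbocycle replaced an aryl group on the same amine nitrogen. The same kind of exchange is made here, so a large rise in number is expected, with a fair chance that compound 4 also reaches only a limit. The step from compound 2 is expected as an 11-fold higher number from compound 2 to compound 4 (1.05 log units; beyond the scatter). Compound 4 is therefore estimated at 20000 nM, within 5000 nM to 80000 nM.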

Compound 4, half-maximal inhibitory concentration: > 8000 nM
Compound 4: only a limit was reported; the forecaster's own chance of this, stated with the estimate: 65%; the middle value does not contradict the limit.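

In this assay, a saturated ring on the amine nitrogen now also costs activity against a second aryl group, 3-methoxyphenyl: an at least 4.4-fold higher number from compound 2 to compound 4 (0.65 log units; beyond the scatter). With both pairs shown moving the same way and neither going against it, the loss no longer rests on a single aryl group or on cyclopentyl alone. Compound 4 gave only a limit of the assay: the limit of > 8000 nM in this assay, at which 1 of the 4 values shown sits.

Compound 3 and compound 4 both stand as limits, so cyclopentyl and cyclohexyl cannot be ordered. Open, as far as these compounds go, is whether a benzyl or an n-butyl group on this amine nitrogen would follow the aryl or the saturated-ring compounds.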